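Aryl urea variations on the benzothiazolylmethoxy phenyl series

The compounds below may be only part of what the source reports. "The series", "measured", "known", "first", "only" and "open" are said of these compounds alone.

Measured compounds in an assay on isolated protein for inhibition of Polyunsaturated fatty acid 5-lipoxygenase (Homo sapiens), read by HPLC, with a stated time of 10 min; on this read-out lower numbers stand for stronger inhibition and higher numbers for weaker inhibition:
compound 1 `Cc1cc(OCc2nc3ccccc3s2)ccc1NC(=O)Nc1ccccc1`, 730 nM
compound 2 `Cc1cc(OCc2nc3ccccc3s2)ccc1NC(=O)Nc1ccccc1Cl`, 830 nM
compound 3 `Cc1cc(OCc2nc3ccccc3s2)ccc1NC(=O)Nc1ccc(Cl)cc1`, 570 nM

Compound 3 gives the lowest of the three numbers, but its gaps to compound 1 and to compound 2 both fall within the scatter, so nothing separates the three on this read-out. The steps measured so far are all small: a 1.1-fold higher number from compound 1 to compound 2 (0.06 log units; within the scatter), a 1.3-fold lower number from compound 1 to compound 3 (0.11 log units; within the scatter) and a 1.5-fold lower number from compound 2 to compound 3 (0.16 log units; within the scatter). Adding a single chloro in either place on the phenyl bound to the urea nitrogen therefore left this assay essentially unchanged.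

Compound 4 `Cc1cc(OCc2nc3ccccc3s2)ccc1NC(=O)Nc1cc(Cl)cc(Cl)c1` carries the change (3,5-dichlorophenyl in place of 4-chlorophenyl on an amide-type nitrogen). Among the compounds with values here, no measured step covers a second chloro on that ring, nor the 3,5-dichlorophenyl itself; the nearest evidence is that one chloro, in two positions, made no difference beyond the scatter. Given that, the expectation for compound 4 is a step of a 1.0-fold lower number from compound 3 to compound 4 (0.02 log units; within the scatter), meaning no change beyond the scatter in either direction. Compound 4 is thus estimated at 550 nM in this assay, with a range from 220 nM to 1400 nM to allow for the untested second chloro.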

Compound 4, half-maximal inhibitory concentration: 80 nM
Beside the measured number, compound 4's estimate is 6.9-fold (0.84 log units) above it; measured number below the stated range.
By their numbers in this assay, from the lowest: compound 4; then compounds 3, 1 and 2 (each within the scatter of the next).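

Within the data shown here, on the amide-type nitrogen, the 3,5-dichlorophenyl group is the first change to move this assay beyond the scatter, with a 7.1-fold lower number from compound 3 to compound 4 (0.85 log units; beyond the scatter), a 10-fold lower number from compound 2 to compound 4 (1.02 log units; beyond the scatter) and a 9.1-fold lower number from compound 1 to compound 4 (0.96 log units; beyond the scatter). The single chloro steps, a 1.1-fold higher number from compound 1 to compound 2 (0.06 log units; within the scatter) and a 1.3-fold lower number from compound 1 to compound 3 (0.11 log units; within the scatter), stayed within the scatter, so at this position one chloro in either of the two places shown gives no separation, whereas compound 4 stands apart from compounds 1, 2 and 3. Among these compounds, no supporting measurement is available to explain the difference between the 3,5-dichlorophenyl group and the single chloro compounds.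

As far as these compounds go, whether the step belongs to chloro itself remains open, as does whether it would hold with bromo, trifluoromethyl or methoxy groups on that ring, or with a carboxylic acid or an amine there. All four compounds keep the shared core, so it cannot be told whether the 3,5-dichlorophenyl step carries over to a different core or to one lacking the methyl group.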